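A few compounds are considered here, and "the series" means these few. Any claim that something is new, unique, unknown or untested is made for them only; others in the source may bear on it.

Working notes on the series

Compound 1, `COc1ccc(-c2ccc(OC)c3oc(C(=O)Nc4ccc(Cn5ccnc5)cc4)cc23)cc1`, has no single number in an in vitro ADME assay on microsomes from liver (Rattus norvegicus) for metabolic stability; a higher number here means faster removal of the compound, a lower number slower removal: the read-out for compound 1 is recorded as "not determined" (no result reported), so compound 1 stands at no point on the clearance scale and gives no anchor of its own. Among the measured compounds shown here, the only measured member is compound 2, `COc1ccc(-c2ccccc2)c2cc(C(=O)Nc3ccncc3)oc12`, which in this assay gives 580 mL/min/kg, a very rapid removal.

Compound 3, `COc1ccc(-c2ccccc2)c2cc(C(=O)Nc3ccc(Cn4ccnc4)cc3)oc12`, is reached from compound 1 by the change (hydrogen in place of methoxy on an aromatic carbon). The amide side and the shared core are kept unchanged; only the substituent on the outer six-membered ring is removed. Compound 3 carries the same unsubstituted phenyl as compound 2 and differs from compound 2 only in the amide amine part, a pair for which no step is shown.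

For the measured compounds named here, with no value for compound 1, no step in this assay from compound 1 to compound 3 can be given a size or a direction; the expectation for compound 3 rests on compound 2 alone. Because compound 2 gives 580 mL/min/kg, compound 3 is expected to show clearance in the same high region, estimated at 400 mL/min/kg with a range of 150 mL/min/kg to 1000 mL/min/kg.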

Compound 3, clearance: 2600 mL/min/kg
The estimate for compound 3 lay 6.5-fold (0.81 log units) below the measured number; measured number above the stated range.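

Among the compounds shown here, compound 1 gives "not determined" (no result reported) in this assay and so no step to compound 3 can be read from these results. No evidence at hand bears on the result for compound 3. The compounds shown leave open how 4-methoxyphenyl and phenyl compare for clearance when all else is kept the same.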